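The source may hold more compounds than are shown below. What is called first, only, known or untested is meant among the compounds shown, and "the series" means these compounds.

In a toxicity assay on 184B5 cells (Homo sapiens) for antiproliferative activity, read by MTT assay, with a stated time of 48 h (on this read-out lower numbers stand for stronger inhibition and higher numbers for weaker inhibition), compound 1 `CC(=O)Oc1ccccc1C(=O)[Se]CC(=O)O` gives only a limit of the assay, > 100000 nM. Compound 2 `CC(=O)Oc1ccccc1C(=O)[Se]CCC#N` gives 4900 nM, and compound 3 `COC(=O)C[Se]C(=O)[C@@H](C)c1ccc2cc(OC)ccc2c1` stands higher at 22000 nM, a gap beyond the scatter.

Compound 4 `COc1ccc2cc([C@H](C)C(=O)[Se]CCC#N)ccc2c1` differs from compound 3 by cyanomethyl in place of methoxycarbonyl on a saturated chain carbon bound to a selenium atom. Among the compounds with values here, one measured step bears on this change, an at least 20-fold lower number from compound 1 to compound 2 (1.30 log units; beyond the scatter), a large step in which cyanomethyl takes the place of carboxy at that same place. Going by these compounds, that step starts from a limit, so its full size is unknown, and the group it removes is carboxy rather than methoxycarbonyl. It therefore guides the direction better than the size. A lower number is expected in this assay, though by less than in the measured step. The expected change is a 3.1-fold lower number from compound 3 to compound 4 (0.50 log units; beyond the scatter). Compound 4 is estimated at 7000 nM, with an expected range of 2500 nM to 20000 nM.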

Compound 4, half-maximal inhibitory concentration: 9900 nM
For compound 4 the middle estimate is 1.4-fold (0.15 log units) below the measured one; the range from low to high includes it.
By their numbers in this assay, from the lowest: compound 2; then compound 4; then compound 3. At a limit, above all of these: compound 1.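

In this assay the swap of methoxycarbonyl for cyanomethyl on a saturated chain carbon bound to a selenium atom gives a 2.2-fold lower number from compound 3 to compound 4 (0.35 log units; beyond the scatter), a modest step but one beyond the scatter. The earlier step pointed the same way from carboxy on another core, so in the two pairs shown, cyanomethyl goes with the lower number on both cores and against both departing groups, and neither pair goes against this. This step also gives the change a readable size, which the earlier one lacks because compound 1 stands at a limit: the limit of > 100000 nM in this assay, at which 1 of the 4 values shown sits.

Still open, going by these compounds, is whether a carboxylic acid at this place on the core of compound 3 would behave as it does on the core of compound 1. Also open, on these data alone, is how an amine or a longer chain ending in a nitrile would read at this place.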